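A Fluoro-Methyl Phenyl Swap on a Shared Amide Core

The source may report more compounds than this note shows. Statements on the series, on what has been measured and on what is new or still open speak of the compounds shown alone.

Three measured compounds share one core and differ only in the ring attached to the amide carbonyl. Compound 1 `O=C(Nc1cccc(-c2oc3cc(-c4ccc(F)cc4)ccc3c(=O)c2O)c1)c1ccc(F)cc1` gives 5350 nM in a functional assay on HeLa cells (Homo sapiens) for antiproliferative activity, read by CCK-8 assay, with a stated time of 72 h; a higher number here means a weaker inhibitor, a lower number a stronger inhibitor; compound 2 `Cc1ccc(C(=O)Nc2cccc(-c3oc4cc(-c5ccc(F)cc5)ccc4c(=O)c3O)c2)cc1` gives 6190 nM; compound 3 `COc1cccc(C(=O)Nc2cccc(-c3oc4cc(-c5ccc(F)cc5)ccc4c(=O)c3O)c2)c1` gives 5650 nM. Compound 3 thus sits second highest of the three, with compound 1 nearest and compound 2 furthest, all within the scatter. Compound 4 `Cc1cc(C(=O)Nc2cccc(-c3oc4cc(-c5ccc(F)cc5)ccc4c(=O)c3O)c2)ccc1F` differs from compound 3 by 4-fluoro-3-methylphenyl in place of 3-methoxyphenyl on a carbonyl carbon. Among the measured compounds shown here, the steps that bear on this, a 1.2-fold higher number from compound 1 to compound 2 (0.06 log units; within the scatter) and a 1.1-fold lower number from compound 2 to compound 3 (0.04 log units; within the scatter), were both within the scatter, so no step beyond the scatter is expected in this assay. Compound 4 is therefore estimated at 5700 nM, within 3000 nM to 11000 nM, an expected step of a 1.0-fold higher number from compound 3 to compound 4 (0.00 log units; within the scatter).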

Compound 4, half-maximal inhibitory concentration: 18900 nM
The estimate for compound 4 lay 3.3-fold (0.52 log units) below the measured number; the whole stated range lies below it.
By their numbers in this assay, from the lowest: compounds 1, 3 and 2 (each within the scatter of the next); then compound 4.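

In this assay the ring on the amide carbonyl no longer looks indifferent: one added methyl on the 4-fluorophenyl ring gives a 3.5-fold higher number from compound 1 to compound 4 (0.55 log units; beyond the scatter) and takes the number beyond the scatter. The 4-fluoro-3-methylphenyl group likewise separates from 4-methylphenyl in a 3.1-fold higher number from compound 2 to compound 4 (0.48 log units; beyond the scatter) and from 3-methoxyphenyl in a 3.3-fold higher number from compound 3 to compound 4 (0.52 log units; beyond the scatter) as a modest weakening. Nothing available accounts for this shift.

A plain 3-methylphenyl group would show whether the methyl needs the fluoro alongside it. From the compounds shown here alone, a pyridine ring or a cyclohexyl ring on the carbonyl carbon also remains open.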